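The source may report more compounds than this note shows. Statements on the series, on what has been measured and on what is new or still open speak of the compounds shown alone.

Compound 1, `Clc1ccc2c(NCCNc3nccc(Cl)n3)ccnc2c1`, is measured in a physicochemical assay for lipophilicity, read by HPLC, in phosphate buffer, measured as octanol-water partition, with a stated time of 24 h, at pH 7.4 (a higher number here means a more lipophilic compound, a lower number a more polar compound), and gives 0.501, the lower of the two numbers available. The other measured compound, compound 2, `Clc1ccc2c(NCCCCCCCCCCCCNc3nccc(Cl)n3)ccnc2c1`, gives 2.59, and that gap lies beyond the usual scatter. The next compound is compound 3, `Clc1ccc2c(NCCNc3ccnc(Cl)n3)ccnc2c1`, which has the same atoms as compound 1, joined differently: 2-chloropyrimidin-4-yl in place of 4-chloropyrimidin-2-yl on an amine nitrogen. Here, 2-chloropyrimidin-4-yl stands in place of 4-chloropyrimidin-2-yl on an amine nitrogen. Among the compounds with values here, no measured pair shows the effect of this exchange, and the counted features match on both sides. The expectation therefore rests on compound 1 at 0.501, with no step beyond the scatter expected in this assay and no firm direction. The estimated step is a number 0.05 log units lower from compound 1 to compound 3 (within the scatter). Compound 3 is expected at 0.45, with an estimated range from 0.05 to 0.95.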

Compound 3, distribution coefficient: 0.489
For compound 3 the middle estimate is 0.04 log units below the measured one, and the stated range covers the measured number.
By their numbers in this assay, from the lowest: compounds 3 and 1 (each within the scatter of the next); then compound 2.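

In this assay putting 2-chloropyrimidin-4-yl in place of 4-chloropyrimidin-2-yl on an amine nitrogen gives a number 0.01 log units lower from compound 1 to compound 3 (within the scatter) and so leaves no difference that can be told from the scatter. The earlier compounds shown here offered no pair that isolated this exchange, whereas compound 1 and compound 3 do, and on the chain of compound 1 the two chloropyrimidinyl groups, alike in every counted feature, cannot be told apart by this measure. No measurement shown here offers an explanation for this result.

As far as these compounds go, whether the exchange would also make no measurable difference on the longer chain of compound 2 remains open. So does the outcome of replacing the chlorine on the pyrimidine with another group, such as an amine or a methoxy group.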